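The source may hold more compounds than are shown below. What is called first, only, known or untested is meant among the compounds shown, and "the series" means these compounds.

Compound 1 `COc1ccc(N2CCN/C2=N\N)cc1`: 23%
Compound 2 `N=c1c(=O)[nH]nc2n1CCN2c1ccccc1Cl`: 0%

In a functional assay on T47D cells (Homo sapiens) for cytotoxicity, with a stated time of 72 h, tested at 50 ug/mL (a higher number here means a stronger effect of the compound at the concentration tested, a lower number a weaker effect), compound 1 gives 23%. In this assay, going by the values given here, compound 2 gives 0%, the lowest of the two numbers so far; its nearest neighbour is compound 1, whose number lies higher by a gap that exceeds the usual scatter of such measurements. Among the compounds with values here, no two of the measured compounds differ in just one place, so no measured step in this assay directly guides the next comparison. Compound 3 `N=c1c(=O)[nH]nc2n1CCN2c1ccccc1` is not yet measured. It is derived from compound 2 by a single change: hydrogen in place of chloro on an aromatic carbon. The change sits on an aromatic carbon of a six-membered aromatic ring of carbon only, ortho to a large group. Within the data shown here, with no measured step of this kind available, the expected step of a number 6 percentage points higher from compound 2 to compound 3 (within the scatter) is small, within the scatter or only slightly upward. Compound 3 is therefore expected to give 6% in this assay, most likely between 0% and 25%.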

Compound 3, a percentage reported as inhibition, at one concentration (the size of the read-out at that concentration, not a potency): 3%
Compound 3: middle estimate off by 3 percentage points, on the high side; low and high end bracket the measured number.
By their numbers in this assay, from the lowest: compounds 2 and 3 (each within the scatter of the next); then compound 1.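

In this assay, putting hydrogen in place of chloro on an aromatic carbon, ortho to a large group, gives a step of a number 3 percentage points higher from compound 2 to compound 3 (within the scatter). Going by these compounds alone, this is the first comparison here between two compounds that differ in one place, and it shows that the two cannot be told apart with or without this chlorine atom. Nothing measured here accounts for this result.

As far as these compounds go, only chloro and hydrogen have been compared at this place, so it remains open whether an amine or a carboxylic acid there would give a clearly higher number in this assay. Compound 1 differs from both compounds in more than one place, so its higher number cannot be tied to any single group.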